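Removing the Last Fluorine from a Sulfonyl Aryl Ring

The source may report more compounds than this note shows. Statements on the series, on what has been measured and on what is new or still open speak of the compounds shown alone.

Measured compounds in an assay on isolated protein for displacement of a labelled ligand from metabotropic glutamate receptor 5 (Homo sapiens), with a stated time of 60 min, tested at 1 uM; a lower number here means less inhibition, a higher number more inhibition at the concentration tested (going by the name of the read-out):
compound 1, `Cc1cc(C)cc(S(=O)(=O)c2cnc3ccc(C)cc3c2N2CCC(C)CC2)c1`, 80%
compound 2, `Cc1ccc2ncc(S(=O)(=O)c3cc(F)cc(F)c3)c(N3CCC(C)CC3)c2c1`, 72%
compound 3, `Cc1ccc2ncc(S(=O)(=O)c3cccc(F)c3)c(N3CCC(C)CC3)c2c1`, 94%

Of the three measured compounds, compound 3 stands highest, and its lead over the other two goes beyond the usual scatter: a number 14 percentage points higher from compound 1 to compound 3 (beyond the scatter) and a number 22 percentage points higher from compound 2 to compound 3 (beyond the scatter). Compound 1 and compound 2 differ from each other only within that scatter, a number 8 percentage points lower from compound 1 to compound 2 (within the scatter).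

Compound 4, `Cc1ccc2ncc(S(=O)(=O)c3ccccc3)c(N3CCC(C)CC3)c2c1`, has not yet been measured. It differs from compound 3 in a single spot: hydrogen in place of fluoro on an aromatic carbon. Seen one bond further out, the change reads 3-fluorophenyl to phenyl.

Among the measured compounds shown here, the step that bears most directly on this is the one from compound 2 to compound 3, which is the same kind of swap on the same ring, a number 22 percentage points higher from compound 2 to compound 3 (beyond the scatter). Compound 3 already lies near the top of the inhibition scale, so the room for a further rise is small. On that basis the move to compound 4 is expected to be flat or slightly upward, within the scatter, a number 2 percentage points lower from compound 3 to compound 4 (within the scatter). Compound 4 is therefore estimated at 92%, with a likely range from 78% to 100%.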

Compound 4, a percentage reported as inhibition, at one concentration (the size of the read-out at that concentration, not a potency): 67%
The estimate for compound 4 lay 25 percentage points above the measured number; the measured number lies below the stated range.
By their numbers in this assay, from the lowest: compounds 4, 2 and 1 (each within the scatter of the next, the first and the last beyond it); then compound 3.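

In this assay the lone fluoro on the 3-fluorophenyl ring proves to matter, with a number 27 percentage points lower from compound 3 to compound 4 (beyond the scatter) once hydrogen replaces it. The same kind of swap went the other way at a number 22 percentage points higher from compound 2 to compound 3 (beyond the scatter), so the effect of removing a fluoro from this ring depends on what else the ring carries, and the high value comes only with one fluoro, not with two or none. The bare phenyl ring cannot be told apart from 3,5-difluorophenyl, as a number 5 percentage points lower from compound 2 to compound 4 (within the scatter) shows, but it does fall short of 3,5-dimethylphenyl, with a number 13 percentage points lower from compound 1 to compound 4 (beyond the scatter), and no measurement shown here offers a reason for this rise and fall.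

The compounds shown leave open whether the high value belongs to fluoro itself or would also appear with a single chloro, methyl or methoxy group in its place. They also leave open how these compounds rank in true potency, since each number comes from one tested concentration and compound 3 sits close to the top of the scale.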